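A few compounds are considered here, and "the series" means these few. Any claim that something is new, unique, unknown or untested is made for them only; others in the source may bear on it.

Measured in a functional assay on PC-3 cells (Homo sapiens) for inhibition, read by sulforhodamine B assay; on this read-out lower numbers stand for stronger inhibition of growth and higher numbers for weaker inhibition of growth:
- compound 1 `COc1ccc(-c2ccc(-c3ccc(-c4nc5cc(C)ccc5[nH]4)cc3)cc2)cc1OC`: 2560 nM
- compound 2 `Cc1ccc2[nH]c(-c3ccc(-c4ccc(-c5ccc(F)cc5)cc4)cc3)nc2c1`: 100000 nM

Compound 2 has the higher of the two numbers, at 100000 nM, and so shows the weaker inhibition of growth. The next compound is compound 3 `Cc1ccc2[nH]c(-c3ccc(-c4ccc(-c5ccc(C(F)(F)F)cc5)cc4)cc3)nc2c1`, which differs from compound 2 by trifluoromethyl in place of fluoro on an aromatic carbon, para to a large group.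

For the measured compounds named here, only one measured step bears on this change, and only indirectly. It is a 39-fold higher number from compound 1 to compound 2 (1.59 log units; beyond the scatter), a large step beyond the scatter, with 4-fluorophenyl in place of 3,4-dimethoxyphenyl on an aromatic carbon. Going by the values given here, that step involves a different pair of groups, and no measured compound carries trifluoromethyl, so the data give no direct size for the new change. Compound 3 also lacks the 3,4-dimethoxyphenyl group, and with compound 2 at 100000 nM no step beyond the scatter is expected in this assay.

The expected step is a 1.4-fold lower number from compound 2 to compound 3 (0.15 log units; within the scatter), which stays within the scatter. For compound 3 the estimated value is 70000 nM, with an expected range of 15000 nM to 150000 nM.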

Compound 3, concentration for 50% growth inhibition: 2010 nM
For compound 3 the middle estimate is 35-fold (1.54 log units) above the measured one; the whole stated range lies above it.
By their numbers in this assay, from the lowest: compounds 3 and 1 (each within the scatter of the next); then compound 2.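

In this assay, for the compounds shown here, a single change on the aromatic carbon para to a large group spans the full range of the series so far, with trifluoromethyl in place of fluoro giving a 50-fold lower number from compound 2 to compound 3 (1.70 log units; beyond the scatter). Removing 3,4-dimethoxyphenyl therefore does not by itself account for the high number of compound 2, since the swap to 4-(trifluoromethyl)phenyl gives a 1.3-fold lower number from compound 1 to compound 3 (0.11 log units; within the scatter), leaving two quite different terminal aryl groups level within the scatter and making the fluoro compound the outlier among the three. No measurement at hand explains why fluoro and trifluoromethyl differ so widely at this position.

Still open, as far as these compounds go, is where other groups on this carbon would fall, such as chloro, methyl, an amine or a carboxylic acid, and whether they would group with compound 2 or with compound 1 and compound 3. Also open, from the compounds shown here alone, is whether the large gap between fluoro and trifluoromethyl would persist if the methyl group on the shared core were replaced by a longer chain.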